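A further aromatic ring on the carbonyl carbon

The source may hold more compounds than are shown below. What is called first, only, known or untested is meant among the compounds shown, and "the series" means these compounds.

compound 1 `CCCCCCCCCCCC[C@@H](O)[C@H]1CC[C@H]([C@H](O)CCCCCCCCCCNC(=O)c2ccoc2)O1` gives 100000 nM
compound 2 `CCCCCCCCCCCC[C@@H](O)[C@H]1CC[C@H]([C@H](O)CCCCCCCCCCNC(=O)c2cncs2)O1` gives 100000 nM

In a functional assay on SNB-78 cells (Homo sapiens) for inhibition, read by colorimetric assay and sulforhodamine B assay, with a stated time of 48 h (a lower number here means a stronger inhibitor of growth, a higher number a weaker inhibitor of growth), compound 2 gives 100000 nM and so stands level with compound 1 at the digits shown. Compound 3 `CCCCCCCCCCCC[C@@H](O)[C@H]1CC[C@H]([C@H](O)CCCCCCCCCCNC(=O)c2ccnn2C)O1` carries a new swap at the same place (1-methyl-1H-pyrazol-5-yl in place of 1,3-thiazol-5-yl on a carbonyl carbon) with 1-methyl-1H-pyrazol-5-yl in place of 1,3-thiazol-5-yl on a carbonyl carbon. Among the measured compounds shown here, only one measured step bears on this, the swap of furan-3-yl for 1,3-thiazol-5-yl, which gave no change at the digits printed from compound 1 to compound 2 (within the scatter) and is thin evidence, yet it points to no expected step beyond the scatter. The estimated step is no change at the digits printed from compound 2 to compound 3 (within the scatter) in this assay for this swap. Compound 3 is estimated at 100000 nM with an expected range of 30000 nM to 100000 nM for repeat measurements.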

Compound 3, concentration for 50% growth inhibition: 100000 nM
Estimate against measurement, compound 3: no gap at the digits printed, within the range that was stated.
By their numbers in this assay, from the lowest: compounds 1, 2 and 3 (each within the scatter of the next).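

Set on the carbonyl carbon, the 1-methyl-1H-pyrazol-5-yl ring gives no change at the digits printed from compound 2 to compound 3 (within the scatter) and no change at the digits printed from compound 1 to compound 3 (within the scatter) in this assay. This extends the flat picture to a third five-membered aromatic ring, now one with a methyl group and two nitrogens, one more heavy atom than 1,3-thiazol-5-yl and no sulfur. Nothing available explains why these swaps leave the value unmoved.

On these data alone, whether a six-membered ring such as pyridine or phenyl would give a different value remains open. So does the effect of a non-aromatic group here, such as a carboxylic acid.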